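This account rests on a few compounds, and the source may have more. Where it says the series, first, only, none or still open, it means among the compounds named here.

In a functional assay on MCF7 cells (Homo sapiens) for antiproliferative activity, read by MTT assay, with a stated time of 48 h (a lower number here means a stronger inhibitor, a higher number a weaker inhibitor), compound 1 `Cc1c(C(=O)NCCCN(C)C)oc2ccc(N(Cc3ccc(Br)cc3)S(=O)(=O)c3ccc(Br)cc3)cc12` gives 3710 nM, while compound 2 `Cc1c(C(=O)NCC(O)CO)oc2ccc(N(Cc3ccc(Br)cc3)S(=O)(=O)c3ccc(Br)cc3)cc12` gives 36500 nM, the higher of the two numbers. Compound 3 `Cc1ccc(NC(=O)c2oc3ccc(N(Cc4ccc(Br)cc4)S(=O)(=O)c4ccc(Br)cc4)cc3c2C)nc1` keeps the shared core but has 5-methylpyridin-2-yl in place of 2,3-dihydroxypropyl on an amide-type nitrogen. Among the measured compounds shown here, only one measured step bears on this change, and it is an indirect guide. It is a 9.8-fold higher number from compound 1 to compound 2 (0.99 log units; beyond the scatter), made by swapping 2-(dimethylamino)ethyl for 1,2-dihydroxyethyl on a saturated chain carbon bound to an amide-type nitrogen. For the measured compounds named here, no measured compound carries an aromatic ring at this place. A move of somewhat smaller size towards a lower number is therefore expected in this assay, though with wide uncertainty. The expected change is a 3.0-fold lower number from compound 2 to compound 3 (0.48 log units; beyond the scatter). For compound 3 the estimated value is 12000 nM, with an expected range from 3000 nM to 45000 nM.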

Compound 3, half-maximal inhibitory concentration: > 40000 nM
Compound 3: a limit, no number; the forecaster's own chance of this, stated with the estimate: 15%; middle value at least 3.3-fold (0.52 log units) from the limit.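

In this assay, from the compounds shown here alone, compound 3 gives no number, only a limit: the limit of > 40000 nM in this assay, at which 1 of the 3 values shown sits. With 5-methylpyridin-2-yl on the amide-type nitrogen, the read-out shows an at least 1.0-fold higher number from compound 2 to compound 3 (0.03 log units; that floor lies within the scatter), so an aromatic ring at this place does not bring the number down from that of compound 2, although the true size of the gap stays unknown. The step from the basic-free comparison is clearer at the other end, with an at least 10-fold higher number from compound 1 to compound 3 (1.03 log units; beyond the scatter), so 3-(dimethylamino)propyl gives a lower number than either replacement shown here.

Going by these compounds, how far compound 3 lies past its limit remains open. Also open, on these data alone, is how a phenyl ring without the ring nitrogen, a pyridin-2-yl group without the methyl, a longer chain ending in dimethylamino, or a carboxylic acid would read at this amide-type nitrogen.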